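The source may report more compounds than this note shows. Statements on the series, on what has been measured and on what is new or still open speak of the compounds shown alone.

Measured so far:
compound 1, `Nc1cc(N)c2nc(-c3ccccc3)c(Oc3ccc(Cl)c(Cl)c3)nc2c1`, < 100000 nM
compound 2, `Nc1cc(N)c2nc(-c3ccccc3)c(NCc3ccc(Cl)c(Cl)c3)nc2c1`, 3720 nM
compound 3, `CCOC(=O)[C@H](CCC(=O)O)NC(=O)c1ccc(Sc2nc3cc(N)cc(N)c3nc2-c2ccccc2)cc1`, < 100000 nM

In a functional assay on RPMI8266 cells (Homo sapiens) for inhibition, read by sulforhodamine B assay, with a stated time of 48 h (a lower number here means a stronger inhibitor of growth, a higher number a weaker inhibitor of growth), compound 1 gives only a limit, < 100000 nM, so no number stands for it. Compound 3 likewise returns a limit, < 100000 nM. Compound 2 gives a number, 3720 nM. Two of the three results therefore sit at the limit of < 100000 nM in this assay, at which 2 of the 3 values shown sit, and compound 1 cannot be placed against compound 2 beyond that. Compound 4, `Nc1cc(N)c2nc(-c3ccccc3)c(Sc3ccc(F)cc3)nc2c1`, differs from compound 1 by (4-fluorophenyl)sulfanyl in place of 3,4-dichlorophenoxy on an aromatic carbon. Among the measured compounds shown here, no measured pair differs in a single place, so no step size is known from the data. The change is expected to move the result toward a measurable number, an expected step that the limit leaves unreadable from compound 1 to compound 4. Compound 4 is estimated at 20000 nM, within a range from 3000 nM to 100000 nM.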

Compound 4, concentration for total growth inhibition: 81300 nM
Beside the measured number, compound 4's estimate is 4.1-fold (0.61 log units) below it; the range from low to high includes it.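

No step from compound 1 to compound 4 can be read, because compound 1 gives only a limit: the limit of < 100000 nM in this assay, at which 2 of the 4 values shown sit.

Left open is the size of the change that (4-fluorophenyl)sulfanyl in place of 3,4-dichlorophenoxy brings on the shared core.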